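Amide substituent on the shared core: toward the free acid

The source may hold more compounds than are shown below. What is called first, only, known or untested is meant among the compounds shown, and "the series" means these compounds.

Three amides on the shared core have been run in a functional assay on BXPC-3 cells (Homo sapiens) for antiproliferative activity, read by MTT assay, with a stated time of 24 h; a higher number here means a weaker inhibitor, a lower number a stronger inhibitor. In this assay compound 1 `CCn1c(C(=O)N[C@H](C)C(=O)OC)ccc1C(CC)(CC)c1ccc(OCS(=O)(=O)c2ccccc2)c(C)c1` gives only a limit, > 50000 nM. Compound 2 `CCN(CC)CCNC(=O)c1ccc(C(CC)(CC)c2ccc(OCS(=O)(=O)c3ccccc3)c(C)c2)n1CC` gives 6270 nM, and compound 3 `CCn1c(C(=O)NCCO)ccc1C(CC)(CC)c1ccc(OCS(=O)(=O)c2ccccc2)c(C)c1` gives 19900 nM, the higher of the two plain numbers; the measured steps were an at least 7.9-fold lower number from compound 1 to compound 2 (0.90 log units; beyond the scatter), an at least 2.5-fold lower number from compound 1 to compound 3 (0.40 log units; beyond the scatter) and a 3.2-fold higher number from compound 2 to compound 3 (0.50 log units; beyond the scatter). Compound 4 `CCn1c(C(=O)N[C@H](C)C(=O)O)ccc1C(CC)(CC)c1ccc(OCS(=O)(=O)c2ccccc2)c(C)c1` awaits measurement; the change from compound 3 is 1-carboxyethyl in place of 2-hydroxyethyl on an amide-type nitrogen. The step that bears on it is an at least 2.5-fold lower number from compound 1 to compound 3 (0.40 log units; beyond the scatter), which ran the other way from a 1-(methoxycarbonyl)ethyl group; compound 4 carries the related 1-carboxyethyl group, so a higher number than compound 3 is expected, probably beyond the scatter, with a fair chance of only a limit. For compound 4 the expected step is a 3.0-fold higher number from compound 3 to compound 4 (0.48 log units; beyond the scatter). Compound 4 is thus estimated at 60000 nM, within 20000 nM to 200000 nM.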

Compound 4, half-maximal inhibitory concentration: 20100 nM
Beside the measured number, compound 4's estimate is 3.0-fold (0.47 log units) above it; measured number inside the range.
By their numbers in this assay, from the lowest: compound 2; then compounds 3 and 4 (each within the scatter of the next). At a limit, above all of these: compound 1.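

In this assay, 1-carboxyethyl and 2-hydroxyethyl on the amide-type nitrogen are not told apart: a 1.0-fold higher number from compound 3 to compound 4 (0.00 log units; within the scatter). The 2-(diethylamino)ethyl amide stays separate from the acid, with a 3.2-fold higher number from compound 2 to compound 4 (0.51 log units; beyond the scatter). Hydrogen in place of methyl on the oxygen next to a carbonyl group gives an at least 2.4-fold lower number from compound 1 to compound 4 (0.39 log units; beyond the scatter), which is only a bound since compound 1 stands as a limit: the limit of > 50000 nM in this assay, at which 1 of the 4 values shown sits.

Going by these compounds, whether a longer chain ending in an amine would keep the position of compound 2 remains open. So does whether the opposite configuration of the 1-carboxyethyl stereocentre would match compound 4.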